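Swapping the aryl group on a thiocyanate amide

The compounds below may be only part of what the source reports. "The series", "measured", "known", "first", "only" and "open" are said of these compounds alone.

Measured in a functional assay on K562 cells (Homo sapiens) for antiproliferative activity, read by MTT assay, with a stated time of 72 h; on this read-out higher numbers stand for weaker inhibition of growth and lower numbers for stronger inhibition of growth:
- compound 1 `Cc1c(C(=O)Nc2ccc(SC#N)cc2)nnn1-c1ccc(C(C)C)cc1`: 5400 nM
- compound 2 `Cc1ccc(Cl)cc1-n1nnc(C(=O)Nc2ccc(SC#N)cc2)c1C`: 5700 nM

Still to be measured is compound 3 `COc1cccc(-n2nnc(C(=O)Nc3ccc(SC#N)cc3)c2C)c1`.

For the measured compounds named here, compound 1 has only one measured neighbour, and the two numbers cannot be told apart: a 1.1-fold higher number from compound 1 to compound 2 (0.02 log units; within the scatter). Compound 3 keeps the core of compound 1 and places 3-methoxyphenyl in place of 4-isopropylphenyl on an aromatic nitrogen. Going by the values given here, only one measured step bears on this change, the one above, where 5-chloro-2-methylphenyl replaced the same 4-isopropylphenyl. A single step is thin evidence, but it gives no reason to expect a change beyond the scatter in this assay, in either direction. The expected step is small: a 1.0-fold higher number from compound 1 to compound 3 (0.01 log units; within the scatter). For compound 3 the estimated value is 5500 nM, with an expected range of 2500 nM to 12000 nM.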

Compound 3, concentration for 50% growth inhibition: 84500 nM
For compound 3 the middle estimate is 15-fold (1.19 log units) below the measured one; measured number above the stated range.
By their numbers in this assay, from the lowest: compounds 1 and 2 (each within the scatter of the next); then compound 3.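

The group on this ring nitrogen is not interchangeable: in this assay, 3-methoxyphenyl in place of 4-isopropylphenyl gives a 16-fold higher number from compound 1 to compound 3 (1.19 log units; beyond the scatter), and in place of 5-chloro-2-methylphenyl it gives a 15-fold higher number from compound 2 to compound 3 (1.17 log units; beyond the scatter), both towards weaker inhibition of growth. The two earlier groups sat within the scatter of each other, so they hid how much this position can matter, while the core of compound 1 stayed the same throughout. The change swaps a group with no hydrogen-bond acceptor for one with a single acceptor, but nothing measured here says why the number rises.

The compounds shown leave open whether the methoxy group itself or its place on the phenyl ring goes with the weaker inhibition of growth. Also open, going by these compounds, is how an amine or a longer chain on that phenyl ring would read in this assay.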